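From hydrogen to trifluoromethyl on compound 3

This account rests on a few compounds, and the source may have more. Where it says the series, first, only, none or still open, it means among the compounds named here.

Values in an ADME assay on MDCK cells (Canis lupus familiaris) for cytotoxicity; a higher number here means that more compound is tolerated, a lower number that less compound is tolerated:
- Compound 1 `O=[N+]([O-])C1=CNc2nc(C(F)(F)F)nn2C1c1c(O)cc(O)cc1O` gives 838000 nM 
- Compound 2 `O=[N+]([O-])C1=CNc2nc(-c3ccco3)nn2C1c1ccc(O)cc1O` gives 119000 nM 
- Compound 3 `O=[N+]([O-])C1=CNc2ncnn2C1c1ccc(O)cc1O` gives > 1080000 nM 

Compound 3 stands only at a limit of the assay, (the limit of > 1080000 nM in this assay, at which 1 of the 3 values shown sits), and has no exact number. Compound 4 `O=[N+]([O-])C1=CNc2nc(C(F)(F)F)nn2C1c1ccc(O)cc1O` carries trifluoromethyl in place of hydrogen on an aromatic carbon, (trifluoromethyl in place of hydrogen on an aromatic carbon). Going by the values given here, one measured step bears on that carbon, an at least 9.0-fold higher number from compound 2 to compound 3 (0.95 log units; beyond the scatter), and it shows compound 2 with furan-2-yl at the lower number. Compound 1 also carries trifluoromethyl and gives 838000 nM. Among the compounds with values here, a modest step to a lower number in this assay is therefore expected, smaller than the one seen for compound 2. The expected change is an at least 1.5-fold lower number from compound 3 to compound 4 (0.18 log units; that floor lies within the scatter). Compound 4 is estimated at 700000 nM, with an expected range from 300000 nM to 1300000 nM.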

Compound 4, half-maximal cytotoxic concentration: 258000 nM
Compound 4: the middle estimate sits 2.7-fold (0.43 log units) above what was measured, and the stated range ends above it.
By their numbers in this assay, from the lowest: compound 2; then compound 4; then compound 1. At a limit, above all of these: compound 3.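

In this assay, trifluoromethyl in place of hydrogen on this aromatic carbon also gives a lower number, an at least 4.1-fold lower number from compound 3 to compound 4 (0.62 log units; beyond the scatter), and that size is only a floor because compound 3 stands at a limit: the limit of > 1080000 nM in this assay, at which 1 of the 4 values shown sits. The two groups placed here are not equivalent, with a 2.2-fold higher number from compound 2 to compound 4 (0.34 log units; beyond the scatter). A change elsewhere also counts, as hydrogen in place of hydroxy on an aromatic carbon gives a 3.2-fold lower number from compound 1 to compound 4 (0.51 log units; beyond the scatter).

On these data alone, the full size of the step from hydrogen stays open. As far as these compounds go, how an amine, a methyl or a carboxylic acid on this carbon would compare also stays open.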